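Amino to 2-(benzyloxy)ethoxy on the shared core

The source may hold more compounds than are shown below. What is called first, only, known or untested is meant among the compounds shown, and "the series" means these compounds.

In a functional assay on MCF7 cells (Homo sapiens) for inhibition, with a stated time of 48 h (a higher number here means a weaker inhibitor, a lower number a stronger inhibitor), compound 1 `COc1cc(Sc2c(C)[nH]c3ccccc23)cc(OC)c1OC` gives 46 nM and compound 2 `COc1cc(Sc2c[nH]c3ccc(Br)cc23)cc(OC)c1OC` gives 43 nM, two values within the scatter of each other. Compound 3 `COc1cc(Sc2c[nH]c3ccc(N)cc23)cc(OC)c1OC` gives 260 nM, the highest number of the three, and its gaps to both others lie beyond the scatter.

Compound 4 `COc1cc(Sc2c[nH]c3ccc(OCCOCc4ccccc4)cc23)cc(OC)c1OC` is still unmeasured. The change is 2-(benzyloxy)ethoxy in place of amino on an aromatic carbon of a six-membered aromatic ring of carbon only, part of a fused or bridged system of two rings.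

One measured step changes the group on this carbon: a 6.0-fold higher number from compound 2 to compound 3 (0.78 log units; beyond the scatter), with amino in place of bromo. It shows that the group here can move the number by a modest amount, and that amino gave the higher number of the two groups compared. For the measured compounds named here, no measured compound carries anything resembling 2-(benzyloxy)ethoxy, so this step offers only a rough scale and the direction stays uncertain. A partial return towards compound 2 at 43 nM is the working expectation. The estimated step is a 2.2-fold lower number from compound 3 to compound 4 (0.34 log units; beyond the scatter), a modest move towards a lower number. Compound 4 is estimated at 120 nM, with an expected range of 30 nM to 500 nM.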

Compound 4, half-maximal inhibitory concentration: 260 nM
Compound 4: middle estimate off by 2.2-fold (0.34 log units), on the low side, within the range that was stated.
By their numbers in this assay, from the lowest: compounds 2 and 1 (each within the scatter of the next); then compounds 3 and 4 (each within the scatter of the next).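

In this assay, the exchange of amino for 2-(benzyloxy)ethoxy on this aromatic carbon gives no change at the digits printed from compound 3 to compound 4 (within the scatter), so adding a six-membered aromatic ring and removing the hydrogen-bond donor leaves the read-out level with that of the amino compound. Against bromo, the same group gives a 6.0-fold higher number from compound 2 to compound 4 (0.78 log units; beyond the scatter), which places two quite different groups, amino and 2-(benzyloxy)ethoxy, on the same higher side of bromo, something the single earlier step could not show. No supporting data bear on why these two groups stand level or why both stand apart from bromo.

As far as these compounds go, it remains open whether the low number belongs to bromo alone or extends to other halogens such as chloro or fluoro, and whether a small ether such as methoxy would stand with bromo or with the amino and 2-(benzyloxy)ethoxy compounds. Also open, from the compounds shown here alone, is how much the terminal phenyl ring contributes, which a plain 2-methoxyethoxy or 2-hydroxyethoxy chain at this carbon would help to separate from the effect of the chain itself.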